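Methoxy in place of chloro on compound 2

The source may hold more compounds than are shown below. What is called first, only, known or untested is meant among the compounds shown, and "the series" means these compounds.

Values in a functional assay on HL-60 cells (Homo sapiens) for cytotoxicity, read by luminescence and CellTiter-Glo, with a stated time of 3 days (on this read-out lower numbers stand for stronger inhibition and higher numbers for weaker inhibition), stand as follows
compound 1 `N#Cc1ccc(NC(=O)c2cccc(Br)c2O)cc1` gives 2910 nM
compound 2 `N#Cc1ccc(NC(=O)c2ccc(Cl)cc2O)cc1` gives 1300 nM
compound 3 `O=C(Nc1cc(C(F)(F)F)cc(C(F)(F)F)c1)c1cc(Br)c(F)cc1O` gives 250 nM

Compound 2 sits in the middle of these three numbers, as the second highest. Compound 1 gives a higher number and compound 3 a lower one, and both gaps lie beyond the scatter. No two of the measured compounds differ in one place only, so the series offers no direct measure of a single change.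

The next compound, compound 4 `COc1ccc(C(=O)Nc2ccc(C#N)cc2)c(O)c1`, keeps the structure of compound 2 except at one site, where methoxy stands in place of chloro. The change is methoxy in place of chloro on an aromatic carbon and it sits on an aromatic carbon, meta to a hydroxy group and para to a large group.

In this assay a moderate step toward a higher number is expected, slightly beyond the scatter. Compound 1 also carries the nitrile and stands at 2910 nM and that value guides the expectation. The estimated step is a 2.2-fold higher number from compound 2 to compound 4 (0.33 log units; beyond the scatter) and it remains uncertain. The estimate for compound 4 is 2800 nM with an expected range from 1100 nM to 7500 nM around it.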

Compound 4, half-maximal inhibitory concentration: 5470 nM
Compound 4: the middle estimate sits 2.0-fold (0.29 log units) below what was measured; measured number inside the range.
By their numbers in this assay, from the lowest: compound 3; then compound 2; then compounds 1 and 4 (each within the scatter of the next).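

Here, for the first time in the series, a single change can be read on its own: in this assay, methoxy in place of chloro on an aromatic carbon, meta to a hydroxy group and para to a large group, gives a 4.2-fold higher number from compound 2 to compound 4 (0.62 log units; beyond the scatter) with the rest of the structure held constant. As this step lies beyond the scatter, the position is sensitive to the exchange of these two groups, and of the pair, chloro is the one that goes with the lower number on this core. The compounds shown offer no measurement that would explain the step, so it stands as an observation only.

From the compounds shown here alone, it remains open how this same aromatic carbon would respond to an amine, a carboxylic acid or a longer chain such as ethoxy, and so whether the result reflects something particular to methoxy or a wider trend among groups placed there. Going by these compounds, it is also open whether the exchange of chloro for methoxy would give a step of similar size on the core of compound 3, which differs from compound 2 in more than one place.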